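The source may report more compounds than this note shows. Statements on the series, on what has been measured and on what is new or still open speak of the compounds shown alone.

Compound 1, `COc1ccc(-c2cc(C(C)(C)C)cc(C(C)C)c2CO)cc1`, gives 1300 nM in a functional assay on RKE cells for antagonist activity at Vasoactive intestinal polypeptide receptor 1 (Rattus norvegicus), read by HTRF and cAMP accumulation, with stated times of 10 min and 30 min; on this read-out lower numbers stand for stronger inhibition and higher numbers for weaker inhibition.
Compound 2, `CC(C)c1cc(C(C)(C)C)cc(-c2ccc(-c3ccccc3)cc2)c1CO`, gives 680 nM in this assay.
Compound 3, `CC(C)c1cc(C(C)(C)C)cc(-c2cccc(-c3ccccc3)c2)c1CO`, gives 210 nM in this assay.

Compound 3 has the lowest number of the three; the difference between its core and that of compound 2 is not broken down here. Between compound 2 and compound 1 the change is methoxy in place of phenyl on an aromatic carbon, and it gave a 1.9-fold higher number from compound 2 to compound 1 (0.28 log units; within the scatter). Compound 4, `COc1cccc(-c2cc(C(C)(C)C)cc(C(C)C)c2CO)c1`, has not yet been measured in this assay. It arises from compound 3 by methoxy in place of phenyl on an aromatic carbon, the same kind of change, though here the place is meta to a large group rather than para to a large group. The expected step is a 2.0-fold higher number from compound 3 to compound 4 (0.30 log units; within the scatter), resting on the earlier step of a 1.9-fold higher number from compound 2 to compound 1 (0.28 log units; within the scatter). Compound 4 is therefore estimated at 420 nM, likely between 150 nM and 1300 nM.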

Compound 4, half-maximal inhibitory concentration: 200 nM
Compound 4: middle estimate off by 2.1-fold (0.32 log units), on the high side, and the stated range covers the measured number.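

In this assay, putting methoxy in place of phenyl on the core of compound 3 gave a 1.1-fold lower number from compound 3 to compound 4 (0.02 log units; within the scatter). Set beside the same change on the other core, the two steps cannot be told apart: the same change on two cores in this assay, a 1.9-fold higher number (0.28 log units; within the scatter) from compound 2 to compound 1 and a 1.1-fold lower number (0.02 log units; within the scatter) from compound 3 to compound 4, 2.0-fold (0.30 log units) apart, within the scatter of two such steps. In these two pairs, then, the change leaves the number within the scatter on either core, but two pairs cannot show that this would hold on a third core or at another place on the ring.

The compounds shown have only phenyl or methoxy at this place on the ring. As far as these compounds go, how an amine, a carboxylic acid or a longer chain would behave there remains open.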